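The compounds below may be only part of what the source reports. "The series", "measured", "known", "first", "only" and "open" are said of these compounds alone.

Among the measured compounds shown here, in a functional assay on HCT-116 cells (Homo sapiens) for antiproliferative activity, read by MTT assay, with a stated time of 48 h (on this read-out higher numbers stand for weaker inhibition and lower numbers for stronger inhibition), compound 2 `CCCCCCCCCCCC(CCO)n1cnc2c(OC)ncnc21` gives 8230 nM, the only true number so far. Compound 1 `CCCCCCC(CCO)n1cnc2c(N(C)C)ncnc21`, which also carries dimethylamino, gives > 50000 nM, and this value is a limit of the assay. Compound 3 `CCCCCCCCCCCC(CCO)n1cnc2c(N(C)C)ncnc21` leaves the rest of compound 2 unchanged and alters a single group: dimethylamino in place of methoxy on an aromatic carbon. This puts dimethylamino in place of methoxy on an aromatic carbon. For the measured compounds named here, no measured pair shows what this swap does on its own, so any forecast rests on thin evidence. The limit seen for compound 1 at > 50000 nM hints at weaker inhibition, so a small step in that direction is expected, possibly no larger than the usual scatter. The expected step is a 1.3-fold higher number from compound 2 to compound 3 (0.13 log units; within the scatter). For compound 3 the estimated value is 11000 nM, within an expected range of 3500 nM to 35000 nM.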

Compound 3, half-maximal inhibitory concentration: 12000 nM
Estimate against measurement, compound 3: 1.1-fold (0.04 log units) below, and the stated range covers the measured number.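

Swapping methoxy for dimethylamino on this aromatic carbon gives a 1.5-fold higher number from compound 2 to compound 3 (0.16 log units; within the scatter), so with the long chain in place, this change alone has no clear effect on antiproliferative activity. The chain has a clearer effect: with dimethylamino held fixed, pentyl in place of hydrogen on a saturated chain carbon, seven bonds along the chain from an aromatic nitrogen, gives an at least 4.1-fold lower number from compound 1 to compound 3 (0.61 log units; beyond the scatter). Compound 1 stands at a limit rather than a true number, so that step gives only a minimum size: the limit of > 50000 nM in this assay, at which 1 of the 3 values shown sits.

On these data alone, whether a primary amine or a chlorine atom on the same aromatic carbon would shift the number beyond the usual scatter remains open. So does whether a still longer chain would strengthen inhibition further or lose it.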